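Methylating One Phenol Oxygen of a Catechol Scaffold

This account rests on a few compounds, and the source may have more. Where it says the series, first, only, none or still open, it means among the compounds named here.

Compound 1 `C=CC(C)(C/C=C(\C)CCC=C(C)C)c1ccc(O)c(O)c1` carries two free hydroxy groups on its aromatic ring, but in a functional assay on SF-295 cells (Homo sapiens) for cytotoxicity, read by MTT assay, with a stated time of 72 h (a lower number here means a stronger inhibitor, a higher number a weaker inhibitor), compound 1 gives "not determined" (no result reported), so it stands on no number. Its relative compound 2 `C=CC(C)(C/C=C(\C)CCC=C(C)C)c1ccc(O)c(OC)c1`, which carries a methoxy in place of one hydroxy, gives 20.7 ug/mL in this assay. Compound 3 `C=CC(C)(C/C=C(\C)CCC=C(C)C)c1ccc(OC)c(O)c1` differs from compound 1 by methyl in place of hydrogen on an oxygen on an aromatic ring, making it the other single-methyl isomer. With compound 1 unmeasured, no step size can be read; the expectation is simply no difference beyond the usual scatter from compound 2. Compound 3 is expected to give 20 ug/mL, between 8 ug/mL and 50 ug/mL, because compound 2 gives 20.7 ug/mL.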

Compound 3, half-maximal inhibitory concentration: > 25 ug/mL
Compound 3 was reported as a limit; the forecaster's own chance of this, stated with the estimate: 10%; at least 1.2-fold (0.09 log units) between middle value and limit.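

No step can be read from compound 1 to compound 3, as compound 1 has no result. Compound 3 is reported with the limit > 25 ug/mL and no exact number. The compounds shown leave open what replacing either hydroxy with methoxy does to cytotoxicity.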